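From pyridin-2-yl to 3,5-difluorophenyl at the assay limit

The source may report more compounds than this note shows. Statements on the series, on what has been measured and on what is new or still open speak of the compounds shown alone.

Values in a functional assay on Hep 3B2 cells (Homo sapiens) for inhibition, read by sulforhodamine B assay, with a stated time of 72 h; on this read-out higher numbers stand for weaker inhibition and lower numbers for stronger inhibition:
Compound 1 `C[C@H](Nc1ncnc2[nH]cnc12)c1nn(-c2cccc(F)c2)c2cc(F)ccc12`: > 40000 nM (a limit)
Compound 2 `C[C@H](Nc1ncnc2[nH]cnc12)c1nn(-c2ccccn2)c2cc(F)ccc12`: > 40000 nM (a limit)

Within the data shown here, compound 2 has no exact number, only a limit, and the one other value beside it is a limit too. The data so far show only (the limit of > 40000 nM in this assay, at which 2 of the 2 values shown sit). Compound 3 `C[C@H](Nc1ncnc2[nH]cnc12)c1nn(-c2cc(F)cc(F)c2)c2cc(F)ccc12` differs from compound 2 by a single change: 3,5-difluorophenyl in place of pyridin-2-yl on an aromatic nitrogen.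

Among the measured compounds shown here, the one measured step that bears on this is a step that the two limits leave unreadable from compound 1 to compound 2. It put pyridin-2-yl in place of 3-fluorophenyl on the same aromatic nitrogen, so it concerns the same place in the structure, but it gives no size to build on. With no readable step pointing either way, no clear gain in this assay is expected from the new group, and compound 3 may well be reported as a limit again. The expected change is small: a number no higher from compound 2 to compound 3 (the limit leaves the size open). For compound 3 the estimated value is 40000 nM, with an expected range from 20000 nM to 80000 nM.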

Compound 3, half-maximal inhibitory concentration: > 40000 nM
Compound 3: no number, only a limit; the forecaster's own chance of this, stated with the estimate: 80%; the middle value lies on the limit itself.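

Compound 3 gives > 40000 nM in this assay, which is a limit and not an exact number. Among these compounds, no step among compound 1, compound 2 and compound 3 can be read, because all three stop at the same point: the limit of > 40000 nM in this assay, at which 3 of the 3 values shown sit. The compounds shown leave open how strong each one really is, and whether the group on the aromatic nitrogen changes inhibition in this assay at all.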